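The source may report more compounds than this note shows. Statements on the series, on what has been measured and on what is new or still open speak of the compounds shown alone.

Of the compounds shown here, two built on a shared core have been measured in an assay on isolated protein for inhibition of Leucine-rich repeat serine/threonine-protein kinase 2 (Homo sapiens), in the presence of a further agent that is not named here; on this read-out higher numbers stand for weaker inhibition and lower numbers for stronger inhibition. Compound 1 `COc1ccc(OC)c(Sc2ccc3nnc(-c4ccncc4)n3n2)c1` gives 349 nM in this assay. Compound 2 `COc1ccc(OC)c(Sc2ccc3nnc(-c4cnccn4)n3n2)c1` gives 880 nM in this assay. Among the compounds with values here, the one measured step, a 2.5-fold higher number from compound 1 to compound 2 (0.40 log units; beyond the scatter), is a modest weakening. Within the data shown here, on the numbers so far, compound 2 therefore stands at the weaker end of the pair, with compound 1 as its only neighbour.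

Compound 3 `COc1ccc(OC)c(Sc2ccc3nnc(-c4ccsn4)n3n2)c1` is the next compound to be examined. It differs from compound 2 in one place: 1,2-thiazol-3-yl in place of pyrazin-2-yl on an aromatic carbon. Among the measured compounds shown here, no measured step covers a swap of this kind. For the measured compounds named here, the only known step, a 2.5-fold higher number from compound 1 to compound 2 (0.40 log units; beyond the scatter), concerns an exchange of one six-membered ring for another at the same place; it shows that changing the ring there can shift the number modestly, but it says nothing about a five-membered ring carrying sulfur. The expectation for compound 3 is thus a number near that of compound 2, with a wide margin in either direction. The step of a 1.1-fold lower number from compound 2 to compound 3 (0.04 log units; within the scatter) is expected to stay within the scatter. Compound 3 is estimated to give about 800 nM in this assay, with a range from 250 nM to 2500 nM.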

Compound 3, half-maximal inhibitory concentration: 91 nM
For compound 3 the middle estimate is 8.8-fold (0.94 log units) above the measured one, outside the stated range (below it).
By their numbers in this assay, from the lowest: compound 3; then compound 1; then compound 2.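

At the aromatic carbon between two ring nitrogen atoms, a five-membered ring carrying sulfur is not merely tolerated in this assay: 1,2-thiazol-3-yl gives a 9.7-fold lower number from compound 2 to compound 3 (0.99 log units; beyond the scatter) and also a 3.8-fold lower number from compound 1 to compound 3 (0.58 log units; beyond the scatter) so compound 3 is the strongest inhibitor of the three. These steps also show that this position can respond more to a change of ring than the exchange of one six-membered ring for another had suggested, even though pyrazin-2-yl and 1,2-thiazol-3-yl have the same counts of hydrogen-bond donors and acceptors and no net charge. Nothing available here explains why this ring gives the lowest number.

Within the data shown here, only one five-membered ring appears at this position, so it stays open whether the sulfur, the ring size or the arrangement of the ring atoms goes with the lower number. A comparison with 1,3-thiazol-2-yl, with thiophen-2-yl or with 1,2-oxazol-3-yl, where oxygen takes the place of sulfur, would begin to separate these possibilities.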